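Swapping a Methyl for Fluoro on a Sulfonamide Core

The compounds below may be only part of what the source reports. "The series", "measured", "known", "first", "only" and "open" are said of these compounds alone.

Three sulfonamides sharing one core were tested in a functional assay on KB cells (Homo sapiens) for antiproliferative activity, read by sulforhodamine B assay, tested at 100 ug/mL; on this read-out higher numbers stand for more inhibition at the one concentration tested (going by the name of the read-out) and lower numbers for less inhibition. Compound 2 `Cc1ccc(NS(=O)(=O)C2CCCCC2=O)c(C)c1` gives 7.97%, the highest of the three numbers. Compound 3 `O=C1CCCCC1S(=O)(=O)Nc1ccc(Cl)cc1` gives -3.83%, and compound 1 `O=C1CCCCC1S(=O)(=O)Nc1ccccc1Br` gives -14.4%; both lie beyond the usual scatter below compound 2, whose number in this assay is thus the highest of the measured set. Compound 4 `Cc1cc(F)ccc1NS(=O)(=O)C1CCCCC1=O` is not yet measured in this assay. It differs from compound 2 in one place: fluoro in place of methyl on an aromatic carbon. For the measured compounds named here, no pair of measured compounds isolates this change, so the expectation rests on the uniformly low numbers of the set. For compound 4 the value in this assay is estimated at 2%, with a range from -15% to 18%. This means an expected step of a number 6 percentage points lower from compound 2 to compound 4 (within the scatter), a small decrease that stays within the scatter.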

Compound 4, a percentage reported as inhibition, at one concentration (the size of the read-out at that concentration, not a potency): -3.72%
Beside the measured number, compound 4's estimate is 5.7 percentage points above it; the measured number falls inside the stated range.
By their numbers in this assay, from the lowest: compound 1; then compounds 3 and 4 (each within the scatter of the next); then compound 2.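

In this assay, for the compounds shown here, swapping methyl for fluoro brings a number 11.7 percentage points lower from compound 2 to compound 4 (beyond the scatter) at this aromatic carbon, para to a large group, and this is the first change in the set that can be seen on its own. It shows that the group on this carbon matters for the read-out, although a single concentration says nothing about potency. Going by these compounds, one swap gives no trend, so how an amine or a carboxylic acid at this carbon would behave stays open. No measurement at hand gives a reason for the step.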